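The source may report more compounds than this note shows. Statements on the series, on what has been measured and on what is new or still open speak of the compounds shown alone.

Measured compounds:
- compound 1, `O=[N+]([O-])c1cccc2c1CCN(c1ncnc3c1ncn3[C@@H]1O[C@H](CO)[C@@H](O)[C@H]1O)C2`: 3020 nM
- compound 2, `CCCCSc1nc(N)nc2c1ncn2[C@@H]1O[C@H](CO)[C@@H](O)[C@H]1O`: 12000 nM

Within the data shown here, in an assay on isolated protein for binding affinity to Equilibrative nucleoside transporter 1 (Homo sapiens) (a lower number here means a stronger inhibitor, a higher number a weaker inhibitor), compound 2 gives 12000 nM, which is the higher of the two numbers known so far; the nearest value is that of compound 1, whose number is lower by a step beyond the usual scatter. Compound 3, `CSc1nc(N)nc2c1ncn2[C@@H]1O[C@H](CO)[C@@H](O)[C@H]1O`, is not yet measured and differs from compound 2 in one place: hydrogen in place of propyl on a saturated chain carbon bound to a sulfur. The butylsulfanyl group is thus shortened to methylsulfanyl. Among the measured compounds shown here, no pair of measured compounds shows this same change, so there is no measured step to lean on. Within this small set, compound 2 already sits at the weak end, and trimming the alkyl chain down to a single carbon is expected to weaken binding somewhat further rather than improve it, though a step within the scatter is also plausible. The estimated step from compound 2 to compound 3 is a 2.9-fold higher number from compound 2 to compound 3 (0.46 log units; beyond the scatter), with the number for compound 3 expected at 35000 nM, ranging from 8000 nM to 150000 nM.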

Compound 3, half-maximal inhibitory concentration: 204000 nM
Beside the measured number, compound 3's estimate is 5.8-fold (0.77 log units) below it, and the stated range ends below it.
By their numbers in this assay, from the lowest: compound 1; then compound 2; then compound 3.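

In this assay the change from butylsulfanyl to methylsulfanyl gives a 17-fold higher number from compound 2 to compound 3 (1.23 log units; beyond the scatter) and so costs far more than the weak starting point of compound 2 might suggest. The chain on the sulfur is therefore not a neutral spot on this scaffold, and its length can strongly shift the number. The piece removed is only a propyl, with no ring, no hydrogen-bond donors or acceptors and no net charge, yet that alone separates these two compounds by a large step.

From the compounds shown here alone, with only these two chain lengths, it remains open whether ethylsulfanyl and propylsulfanyl fall on a smooth path between them. Going by these compounds, it is also open whether a longer chain such as hexyl, or a benzyl group or a terminal amine on the sulfur chain, would lower the number further.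

Nothing available explains why the shorter chain fares so much worse.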